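The source may hold more compounds than are shown below. What is called first, only, known or untested is meant among the compounds shown, and "the series" means these compounds.

Measured in an ADME assay on HepG2 cells (Homo sapiens) for cytotoxicity, read by MTT assay, with a stated time of 48 h; a lower number here means a stronger inhibitor, a higher number a weaker inhibitor:
Compound 1 `CC(C)CN1C(=O)/C(=C/c2ccccc2C(F)(F)F)S/C1=N\c1ccccc1`: "not determined" (no result reported)
Compound 2 `COc1ccc(/C=C2\S/C(=N\c3ccccc3)N(CC(C)C)C2=O)cc1OC`: > 100000 nM
Compound 3 `COc1ccc(/C=C2\S/C(=N\c3ccccc3)N(CC(C)C)C2=O)cc1`: "not determined" (no result reported)

Compound 2 is the only one of these with a reported result, and its > 100000 nM is a limit of the assay and not a number. Compound 4 `COc1cc(/C=C2\S/C(=N\c3ccccc3)N(CC(C)C)C2=O)ccc1O` differs from compound 2 by a single change, methoxy to hydroxy: hydrogen in place of methyl on an oxygen on an aromatic ring, with hydrogen in place of methyl on an oxygen on an aromatic ring. For the measured compounds named here, no measured pair shows what this change does in this assay, so no step beyond the scatter is expected, in either direction. The estimated size is a number no higher from compound 2 to compound 4 (the limit leaves the size open). For compound 4 the expected value is 100000 nM, with an estimated range from 30000 nM to 200000 nM.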

Compound 4, half-maximal inhibitory concentration: 89500 nM
The estimate for compound 4 lay 1.1-fold (0.05 log units) above the measured number; the range from low to high includes it.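

In this assay, the change from methoxy to hydroxy gives an at least 1.1-fold lower number from compound 2 to compound 4 (0.04 log units; that floor lies within the scatter). Compound 4 gives 89500 nM, the only actual number among the compounds shown, so this position now has one measured value that is not a limit. The step has only a floor, set by the limit of compound 2: the limit of > 100000 nM in this assay, at which 1 of the 4 values shown sits.

Left open is how a longer chain on this oxygen, such as ethyl, would read in this assay. From the compounds shown here alone, an amine in place of the hydroxy also remains open.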